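The compounds below may be only part of what the source reports. "The series", "measured", "known", "first", "only" and "open" are said of these compounds alone.

Measured in a functional assay on A549 cells (Homo sapiens) for antiproliferative activity, read by MTT assay, with a stated time of 72 h; on this read-out lower numbers stand for stronger inhibition and higher numbers for weaker inhibition:

- Compound 1 (`COc1cc2c(Nc3ccc(C#N)cc3)ncnc2cc1OCCCN1CCC(C)CC1`): 32300 nM
- Compound 2 (`COc1cc2c(Nc3ccc(C#N)cc3)ncnc2cc1OCCCN1CCC(N2CCCCC2)CC1`): 30700 nM
- Compound 3 (`CCN1CCN(CCCOc2cc3ncnc(Nc4ccc(C#N)cc4)c3cc2OC)CC1`): 16000 nM

Compound 1 stands at the upper end of these numbers. The nearest measured step from it is small (a 1.1-fold lower number from compound 1 to compound 2 (0.02 log units; within the scatter)), and the furthest is modest (a 2.0-fold lower number from compound 1 to compound 3 (0.31 log units; beyond the scatter)).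

The next compound to be tested is compound 4 (`COc1cc2c(Nc3cccc(C#N)c3)ncnc2cc1OCCCN1CCC(C)CC1`). It has the same atoms as compound 1, joined differently (3-cyanophenyl in place of 4-cyanophenyl on a nitrogen on an aromatic ring), with 3-cyanophenyl in place of 4-cyanophenyl on a nitrogen on an aromatic ring.

Among the compounds with values here, none of the measured steps changes this group, so the data give no direct evidence on this move. All three steps change the group at the end of the chain instead, and the remaining one is also small (a 1.9-fold lower number from compound 2 to compound 3 (0.28 log units; within the scatter)). They show only how narrowly the three numbers are spread when the cyanophenyl group stays the same.

With no measured support for either direction, the expectation is no step beyond the scatter (a 1.1-fold lower number from compound 1 to compound 4 (0.03 log units; within the scatter)). On these data alone, for compound 4 the estimated value is 30000 nM (expected range 12000 nM to 65000 nM), and the range is kept wide because the move itself is untested.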

Compound 4, half-maximal inhibitory concentration: 18700 nM
The estimate for compound 4 lay 1.6-fold (0.21 log units) above the measured number; low and high end bracket the measured number.
By their numbers in this assay, from the lowest: compounds 3, 4, 2 and 1 (each within the scatter of the next, the first and the last beyond it).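

In this assay, the change of 3-cyanophenyl in place of 4-cyanophenyl on a nitrogen on an aromatic ring gives a 1.7-fold lower number from compound 1 to compound 4 (0.24 log units; within the scatter) and so stays within the usual scatter of the read-out. Within the data shown here, the earlier compounds varied only the group at the end of the chain, so this pair is the first reading on the cyanophenyl group itself, and with 4-methylpiperidin-1-yl held fixed, moving the nitrile around the ring does not separate the two compounds by more than repeat measurements would. No measurement in hand bears on the size of this step.

On these data alone, it remains open whether a phenyl ring carrying a chlorine, a methoxy group or a carboxylic acid in place of the nitrile would read differently on this nitrogen. As far as these compounds go, it also remains open whether the same swap of 3-cyanophenyl for 4-cyanophenyl would stay within the scatter when the chain ends in 4-ethylpiperazin-1-yl or 4-(piperidin-1-yl)piperidin-1-yl, since this one pair carries 4-methylpiperidin-1-yl alone.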